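The source may report more compounds than this note shows. Statements on the series, on what has been measured and on what is new or still open speak of the compounds shown alone.

Measured compounds:
compound 1, `CC(C)NC(=N)c1ccc2oc(-c3cccc(OCCCCCOc4ccccc4)c3)cc2c1`: 10100 nM
compound 2, `c1ccc(OCCCCCOc2cccc(-c3cc4cc(C5=NCCN5)ccc4o3)c2)cc1`: 2600 nM
compound 3, `CC(C)NC(=N)c1ccc2cc(-c3ccc(OCCCOc4ccccc4)cc3)oc2c1`: 49900 nM

All three were tested in an ADME assay on L6 cells (Rattus norvegicus) for cytotoxicity, read by resazurin assay, with a stated time of 70 h; on this read-out higher numbers stand for weaker inhibition and lower numbers for stronger inhibition. Compound 1 and compound 2 share one core and differ in a single place: a group of 5 heavy atoms (3 carbon, 2 nitrogen; one five-membered non-aromatic ring with 2 hetero atoms) in place of a group of 6 heavy atoms (4 carbon, 2 nitrogen; no ring), on an aromatic carbon. That change produced a 3.9-fold lower number from compound 1 to compound 2 (0.59 log units; beyond the scatter). Compound 3 is built on a different core, and the difference between the two cores is not broken down here. Of the three, compound 3 gives the highest number in this assay.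

Compound 4, `c1ccc(OCCCOc2ccc(-c3cc4ccc(C5=NCCN5)cc4o3)cc2)cc1`, remains to be measured. Among the compounds with values here, it differs from compound 3 by a group of 5 heavy atoms (3 carbon, 2 nitrogen; one five-membered non-aromatic ring with 2 hetero atoms) in place of a group of 6 heavy atoms (4 carbon, 2 nitrogen; no ring), on an aromatic carbon, the same change, at the same place, as the one separating compound 1 from compound 2. Because that change gave a 3.9-fold lower number from compound 1 to compound 2 (0.59 log units; beyond the scatter), a step of similar size is expected here, and starting from compound 3 the estimate means a 3.8-fold lower number from compound 3 to compound 4 (0.58 log units; beyond the scatter). Compound 4 is therefore estimated at 13000 nM in this assay, with a likely range from 5000 nM to 35000 nM.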

Compound 4, half-maximal inhibitory concentration: 16800 nM
Compound 4: middle estimate off by 1.3-fold (0.11 log units), on the low side; the range from low to high includes it.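

In this assay, putting the five-membered non-aromatic ring group in place of the group with no ring gave a 3.0-fold lower number from compound 3 to compound 4 (0.47 log units; beyond the scatter). Set beside the earlier case, the change carried over from one core to the other with much the same size: the same change on two cores in this assay, a 3.9-fold lower number (0.59 log units; beyond the scatter) from compound 1 to compound 2 and a 3.0-fold lower number (0.47 log units; beyond the scatter) from compound 3 to compound 4, 1.3-fold (0.12 log units) apart, within the scatter of two such steps. This shows that the step held on these two cores in this assay, but two pairs cannot show that it would hold on any further core, and they do not explain why the number falls.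

The compounds shown leave open what an amine or a carboxylic acid on the same aromatic carbon would do. They also leave open whether the step survives with a longer chain.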